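Fluoro for Methyl on the Saturated-Ring Fused Benzene

The source may hold more compounds than are shown below. What is called first, only, known or untested is meant among the compounds shown, and "the series" means these compounds.

Compound 3 `Cc1ccc2c(c1)CC(c1nc3ccc(-c4ccnc(N)n4)cc3o1)CO2` gives 78 nM in an assay on isolated protein for inhibition of Rho-associated protein kinase 2 (Homo sapiens); on this read-out higher numbers stand for weaker inhibition and lower numbers for stronger inhibition. On the numbers shown it stands highest of the three: compound 1 `Nc1nccc(-c2ccc3nc(C4COc5ccccc5C4)oc3c2)n1` gives 27 nM, and compound 2 `Cc1[nH]ncc1-c1ccc2nc(C3COc4ccccc4C3)[nH]c2c1` gives 9 nM. Within the data shown here, the only measured step that touches the same position is a 2.9-fold higher number from compound 1 to compound 3 (0.46 log units; beyond the scatter), a modest rise on replacing hydrogen with methyl. Compound 4 `Nc1nccc(-c2ccc3nc(C4COc5ccc(F)cc5C4)oc3c2)n1` differs from compound 3 by fluoro in place of methyl on an aromatic carbon. Among the measured compounds shown here, no measured pair sets fluoro against hydrogen or methyl at this place, so the expectation rests on the step from compound 1 to compound 3 alone, and on the change being a small substituent exchanged for another small substituent. Compound 4 is therefore expected to land between compound 1 and compound 3, with a downward step a 2.2-fold lower number from compound 3 to compound 4 (0.35 log units; beyond the scatter) from compound 3. In this assay compound 4 is estimated at 35 nM, with a range of 14 nM to 90 nM.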

Compound 4, half-maximal inhibitory concentration: 15 nM
Compound 4: the middle estimate sits 2.3-fold (0.37 log units) above what was measured; low and high end bracket the measured number.
By their numbers in this assay, from the lowest: compounds 2, 4 and 1 (each within the scatter of the next, the first and the last beyond it); then compound 3.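

At this aromatic carbon, fluoro in place of methyl brings a 5.2-fold lower number from compound 3 to compound 4 (0.72 log units; beyond the scatter) and so shows that the rise seen earlier with methyl does not extend to every small substituent placed here. Fluoro in place of hydrogen gives a 1.8-fold lower number from compound 1 to compound 4 (0.26 log units; within the scatter) and stays within the scatter, so in this assay these two groups cannot be told apart at this place, while methyl stands beyond the scatter from both. Nothing at hand accounts for the difference between fluoro and methyl.

The compounds shown leave open how chloro, a methoxy group or an amine would read at this place. They also leave open whether fluoro would read the same way on the core of compound 2, which gives the lowest number of the series.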